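Short amide chain in the growth inhibition series

The source may hold more compounds than are shown below. What is called first, only, known or untested is meant among the compounds shown, and "the series" means these compounds.

Measured so far in an ADME assay on SJ-G2 cells (Homo sapiens) for cytotoxicity, read by MTT assay, with a stated time of 72 h; on this read-out higher numbers stand for weaker inhibition of growth and lower numbers for stronger inhibition of growth
- compound 1 `CCCCCCCCCCNC(=O)C1C(C(=O)O)[C@@H]2CC[C@H]1O2` gives 10000 nM
- compound 2 `CCOC(=O)c1cn[nH]c1NC(=O)C1C(C(=O)O)[C@@H]2CC[C@H]1O2` gives 10000 nM

Compound 1 stands level with compound 2 at the digits shown, and nothing separates the two beyond the scatter. The two carry quite different groups on the amide of the shared core, yet their values do not part.

The next entry is compound 3 `CCCCNC(=O)C1C(C(=O)O)[C@@H]2CC[C@H]1O2`, which keeps the core of compound 1 and shortens its amide chain. The change is hydrogen in place of hexyl on a saturated chain carbon, four bonds along the chain from an amide-type nitrogen. Among the measured compounds shown here, no measured pair isolates chain length, so the expectation rests on very little. Compound 2 gives 10000 nM with its different amide group, which argues against a large move. In this assay a small shift towards weaker inhibition of growth is expected, possibly no more than the scatter. The estimated change is a 1.4-fold higher number from compound 1 to compound 3 (0.15 log units; within the scatter) in that direction. Compound 3 is estimated at 14000 nM (expected range 5000 nM to 50000 nM).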

Compound 3, concentration for 50% growth inhibition: 10000 nM
Estimate against measurement, compound 3: 1.4-fold (0.15 log units) above; low and high end bracket the measured number.
By their numbers in this assay, from the lowest: compounds 1, 2 and 3 (each within the scatter of the next).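

In this assay, the exchange of hexyl for hydrogen on a saturated chain carbon, four bonds along the chain from an amide-type nitrogen, reads as no change at the digits printed from compound 1 to compound 3 (within the scatter) and gives the series its first step with a single point of difference. Until now, the matching values of compound 1 and compound 2 came from amide groups that differ in more than one place, so they said nothing direct about this chain. The step now shows that, at this position and at the digits printed, the reading of compound 1 is kept when the hexyl portion of its chain is removed, although one exchange cannot establish how the reading depends on chain length in general. No measured evidence bears on this result, and the data give no cause for it.

Going by these compounds, whether a longer chain, or a terminal amine or phenyl ring on the chain, would shift the reading at this position remains open. The compounds shown also leave open whether any change at this amide can separate a compound from the value shared by these three, since a single step with no change marks no direction for the series.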